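Swapping a pyridine for a pyridazine on the shared core

The compounds below may be only part of what the source reports. "The series", "measured", "known", "first", "only" and "open" are said of these compounds alone.

Measured so far:
- compound 1 `Cc1ccc([C@@H](C)Oc2cc3onc(CCC(=O)O)c3cc2Cl)nc1` gives 2.42
- compound 2 `C[C@@H](Oc1cc2sc(=O)n(CCC(=O)O)c2cc1Cl)c1ccccn1` gives 1.81
- compound 3 `O=C(O)CCn1c(=O)oc2cc(OCc3ccccn3)c(Cl)cc21` gives 1.32

These three values come from a physicochemical assay for lipophilicity, read by HPLC, at pH 7.4; on this read-out lower numbers stand for lower lipophilicity and higher numbers for higher lipophilicity. Compound 1 stands highest of the three; its gaps to compound 2 and to compound 3 both lie beyond the usual scatter of this assay, so compound 1 is the most lipophilic of the set.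

Compound 4 `Cc1ccc([C@@H](C)Oc2cc3onc(CCC(=O)O)c3cc2Cl)nn1` has not yet been measured. It differs from compound 1 in one place: 6-methylpyridazin-3-yl in place of 5-methylpyridin-2-yl on a saturated chain carbon bound to an oxygen on an aromatic ring and a saturated chain carbon. Among the compounds with values here, the incoming ring carries one more ring nitrogen than the ring it replaces, and no measured pair here shows this exact exchange.

The step of a number 0.72 log units lower from compound 1 to compound 4 (beyond the scatter) is expected to be a decrease beyond the scatter. For compound 4 the expected value is 1.7, with a range from 1.2 to 2.2.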

Compound 4, distribution coefficient: 2.97
For compound 4 the middle estimate is 1.27 log units below the measured one, outside the stated range (above it).
By their numbers in this assay, from the lowest: compound 3; then compound 2; then compound 1; then compound 4.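

At this position, on a saturated chain carbon bound to an oxygen on an aromatic ring and a saturated chain carbon, gaining a ring nitrogen goes with a step of a number 0.55 log units higher from compound 1 to compound 4 (beyond the scatter) in this assay. Within the data shown here, this is the first change in one place in the set, so a second ring nitrogen here is now seen not to lower the number. Nothing available accounts for this direction.

This is a single exchange on a single core. On these data alone, how a phenyl ring or a pyrimidine would read at this position remains open, as does whether the same exchange gives the same step on the cores of compound 2 and compound 3.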